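Second hydroxymethyl on a pyrrole-thiazolidine core

The source may hold more compounds than are shown below. What is called first, only, known or untested is meant among the compounds shown, and "the series" means these compounds.

Of the compounds shown here, three sharing one fused core have been tested in a functional assay on MCF7 cells (Homo sapiens) for cytotoxicity, read by MTT assay, with a stated time of 96 h; a lower number here means a stronger inhibitor, a higher number a weaker inhibitor. Compound 1 `Cc1c(CO)c(CO)c2n1[C@@H](c1ccccc1)SC2`, which carries two hydroxymethyl groups and a phenyl group, gives 600 nM. Compound 2 `Cc1c(CO)cc2n1CSC2`, with a single hydroxymethyl group and no phenyl group, gives 82300 nM. Compound 3 `Cc1cc(CO)c2n1CSC2`, also with a single hydroxymethyl group, gives 44600 nM.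

Compound 3 stands second highest of the three numbers. Its nearest neighbour is compound 2, and the gap between them lies within the usual scatter, so the two cannot be told apart. Compound 1 is far lower, well beyond the scatter.

Compound 4 `Cc1c(CO)c(CO)c2n1CSC2` has not yet been measured in this assay. It differs from compound 3 in one place: hydroxymethyl in place of hydrogen on an aromatic carbon. This gives compound 4 the same pair of hydroxymethyl groups as compound 1, without the phenyl group. Within the data shown here, no measured pair shows this change alone, so the size of the step is uncertain. Because compound 1 gives 600 nM, a step toward lower numbers is expected for compound 4, though part of the distance to compound 1 may belong to its phenyl group. The expected step is an 8.9-fold lower number from compound 3 to compound 4 (0.95 log units; beyond the scatter). Compound 4 is estimated at 5000 nM, within a range from 1000 nM to 25000 nM.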

Compound 4, half-maximal inhibitory concentration: 21500 nM
The estimate for compound 4 lay 4.3-fold (0.63 log units) below the measured number; the range from low to high includes it.
By their numbers in this assay, from the lowest: compound 1; then compound 4; then compounds 3 and 2 (each within the scatter of the next).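

In this assay, hydroxymethyl in place of hydrogen on an aromatic carbon gives a 2.1-fold lower number from compound 3 to compound 4 (0.32 log units; beyond the scatter) and likewise a 3.8-fold lower number from compound 2 to compound 4 (0.58 log units; beyond the scatter), so a second hydroxymethyl group on the shared core has a real but modest effect from either single-hydroxymethyl compound. Hydrogen in place of phenyl on a saturated ring carbon gives a 36-fold higher number from compound 1 to compound 4 (1.55 log units; beyond the scatter), a much larger step, so most of the low number of compound 1 goes with its phenyl group, at least when both hydroxymethyl groups are present. Nothing in the data explains the size of either step.

The compounds shown leave open whether phenyl would have a step of the same size on a core with only one hydroxymethyl group. They also leave open how an amine, a carboxylic acid or a longer chain would compare with hydroxymethyl on the aromatic carbon.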